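A few compounds are considered here, and "the series" means these few. Any claim that something is new, unique, unknown or untested is made for them only; others in the source may bear on it.

Measured compounds:
Compound 1, `CC(C)[C@H](NC(=S)Nc1cc(C(F)(F)F)cc(C(F)(F)F)c1)c1nc2ccccc2[nH]1`: 28900 nM
Compound 2, `C[C@H](NC(=S)Nc1cc(C(F)(F)F)cc(C(F)(F)F)c1)c1nc2ccccc2[nH]1`: 133000 nM
Compound 3, `CC(C)[C@@H](NC(=S)NCc1ccccc1)c1nc2ccccc2[nH]1`: 12300 nM

Of the compounds shown here, three have been measured in a functional assay on HeLa cells (Homo sapiens) for cytotoxicity, read by MTT assay; a higher number here means a weaker inhibitor, a lower number a stronger inhibitor. In this assay compound 1 gives 28900 nM, and compound 2 gives 133000 nM. Compound 3 gives the lowest of the three numbers, 12300 nM. Compound 1 and compound 3 share the thiourea-benzimidazole motif but differ in the group on the far nitrogen of the thiourea; that difference between the two cores is not broken down here.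

The change from compound 1 to compound 2 is methyl in place of isopropyl on a saturated chain carbon bound to an amide-type nitrogen and an aromatic carbon. It produced a 4.6-fold higher number from compound 1 to compound 2 (0.66 log units; beyond the scatter).

Compound 4, `C[C@@H](NC(=S)NCc1ccccc1)c1nc2ccccc2[nH]1`, is not yet measured. It is related to compound 3 by methyl in place of isopropyl on a saturated chain carbon bound to an amide-type nitrogen and an aromatic carbon, the same change that turned compound 1 into compound 2, at the same place. Resting on that earlier step, compound 4 is expected to show a 4.1-fold higher number from compound 3 to compound 4 (0.61 log units; beyond the scatter) in this assay. The estimate for compound 4 is 50000 nM, with a range from 18000 nM to 140000 nM.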

Compound 4, half-maximal inhibitory concentration: "not active" (no number reported)
No number was reported for compound 4; the estimate stays without a comparison.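

In this assay, going by these compounds alone, compound 4 was reported as "not active" without a number, so no step from compound 3 to compound 4 can be read. Nothing measured here bears on this result. The compounds shown leave open whether methyl in place of isopropyl has the same size of effect with both far-nitrogen groups.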